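Replacing nitro with chloro in compound 1

A few compounds are considered here, and "the series" means these few. Any claim that something is new, unique, unknown or untested is made for them only; others in the source may bear on it.

In a functional assay on U-373MG ATCC cells (Homo sapiens) for inhibition, read by MTT assay, with a stated time of 72 h (on this read-out higher numbers stand for weaker inhibition and lower numbers for stronger inhibition), compound 1 (`CC1(C)CC(NC(=S)Nc2ccc([N+](=O)[O-])cc2)c2cc(Br)ccc2O1`) gives 9000 nM, the middle of three numbers. Compound 2 (`CC1(C)CC(NC(=S)Nc2ccc([N+](=O)[O-])cc2)c2cc(Cl)ccc2O1`) lies lower at 3000 nM, and compound 3 (`CC1(C)CC(NC(=O)Nc2ccc(Cl)cc2)c2cc(Br)ccc2O1`) lies higher at 25000 nM.

Compound 4 (`CC1(C)CC(NC(=S)Nc2ccc(Cl)cc2)c2cc(Br)ccc2O1`) differs from compound 1 as follows: chloro in place of nitro on an aromatic carbon. This places chloro in place of nitro on an aromatic carbon, para to a large group. Within the data shown here, no measured step makes this exchange. Among the measured compounds shown here, the only measured step, a 3.0-fold lower number from compound 1 to compound 2 (0.48 log units; beyond the scatter), is modest, but it is a chloro in place of bromo, so it offers only a rough guide to size. Compound 3, at 25000 nM, also carries the chloro group, but it has a carbonyl where compound 4 has a thiocarbonyl, so it is only a loose hint toward a higher number. A small rise, no larger than that modest step, is therefore expected. The estimated change is a 1.3-fold higher number from compound 1 to compound 4 (0.12 log units; within the scatter). For compound 4 the estimate is 12000 nM, with an expected range from 4000 nM to 35000 nM.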

Compound 4, half-maximal inhibitory concentration: 7000 nM
The estimate for compound 4 lay 1.7-fold (0.23 log units) above the measured number; the range from low to high includes it.
By their numbers in this assay, from the lowest: compound 2; then compounds 4 and 1 (each within the scatter of the next); then compound 3.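

In this assay, among these compounds, the first exchange at this aromatic carbon, para to a large group, gives a 1.3-fold lower number from compound 1 to compound 4 (0.11 log units; within the scatter), so chloro in place of nitro, with its smaller count of heavy atoms and no hydrogen-bond acceptors, leaves the number within the scatter. Compound 4 also gives compound 3 a partner that differs in one place, a thiocarbonyl where compound 3 has a carbonyl: compound 3 gives 25000 nM, and compound 4 gives 7000 nM. No measured property is at hand to explain the result at this position.

The compounds shown leave open how an amine, a carboxylic acid or a methoxy group would read at this carbon. They also leave open whether chloro in place of nitro would read the same on compound 2, which carries chloro in place of bromo.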